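The compounds below may be only part of what the source reports. "The series", "measured", "known", "first", "only" and "open" are said of these compounds alone.

Working notes on the series.

Compound 1 `CS(=O)(=O)N1CCN(CC(O)CN2CCC(CNC(=O)c3cccc4[nH]cnc34)CC2)CC1`, compound 2 `CCc1nc2c(C(=O)NCC3CCN(CC(O)CN4CCN(S(C)(=O)=O)CC4)CC3)cccc2[nH]1` and compound 3 `CC(C)c1nc2c(C(=O)NCC3CCN(CCN4CCN(S(C)(=O)=O)CC4)CC3)cccc2[nH]1` share one core; in an assay on isolated protein for binding affinity to 5-hydroxytryptamine receptor 4 (Homo sapiens) (on this read-out higher numbers stand for weaker inhibition and lower numbers for stronger inhibition), compound 1 gives 6.31 nM, compound 2 gives 0.501 nM and compound 3 gives 0.794 nM. Compound 3 stands second highest of the three numbers: its nearest neighbour is compound 2, within the scatter of it, while compound 1 gives a higher number, a gap beyond the scatter. Among the compounds with values here, the only single-point step measured so far is a 13-fold lower number from compound 1 to compound 2 (1.10 log units; beyond the scatter), which concerns a substituent on the core and not the chain that carries the piperazine.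

Compound 4 `CC(=O)N(C)CC(O)CN1CCC(CNC(=O)c2cccc3[nH]c(C(C)C)nc23)CC1` differs from compound 3 in that chain alone: 2-(acetyl(methyl)amino)-1-hydroxyethyl in place of (4-(methylsulfonyl)piperazin-1-yl)methyl on a saturated chain carbon bound to an amine nitrogen in a ring. Within the data shown here, no measured step touches this end of the molecule, so there is nothing to scale the change against. On these data alone, the methylsulfonylpiperazine is present in all three measured compounds, and its removal is untested. The estimate for compound 4 in this assay therefore rests on a cautious assumption that a larger, more decorated piece is exchanged for a smaller one: compound 4 is expected at 3 nM, in the range 0.5 nM to 20 nM. Expressed as a step, the expectation is a 3.8-fold higher number from compound 3 to compound 4 (0.58 log units; beyond the scatter), a modest loss that is only provisional.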

Compound 4, inhibition constant: 3.98 nM
The estimate for compound 4 lay 1.3-fold (0.12 log units) below the measured number; measured number inside the range.
By their numbers in this assay, from the lowest: compounds 2 and 3 (each within the scatter of the next); then compounds 4 and 1 (each within the scatter of the next).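

In this assay, the end of the molecule that carries the piperazine now has a measured step: a 5.0-fold higher number from compound 3 to compound 4 (0.70 log units; beyond the scatter). The (4-(methylsulfonyl)piperazin-1-yl)methyl group can therefore be replaced on the saturated chain carbon bound to an amine nitrogen in a ring at a modest cost, and the ring and the sulfur are not required for nanomolar binding, with compound 4 at 3.98 nM carrying the open-chain 2-(acetyl(methyl)amino)-1-hydroxyethyl group. Nothing available bears on what lies behind this step.

The exchange alters the ring, the sulfur and the hydroxyl-bearing chain together in one step, and which of these accounts for the difference stays open. Also open, on these data alone, is how a plain dimethylamino group or a carboxylic acid on the same saturated chain carbon would read in this assay, and whether the size of this step would hold with the ethyl group of compound 2 on the core in place of the substituent shared by compound 3 and compound 4.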